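Aryloxy variation on a thiazolidinedione series

The compounds below may be only part of what the source reports. "The series", "measured", "known", "first", "only" and "open" are said of these compounds alone.

Measured so far:
- compound 1 `Cc1cccc(Oc2ccc(CC3SC(=O)NC3=O)cc2)n1`, 2620 nM
- compound 2 `Cc1cc(Oc2ccc(CC3SC(=O)NC3=O)cc2)cc(C)c1C#N`, 120 nM
- compound 3 `COc1cc(Oc2ccc(Cl)cc2Cl)ccc1CC1SC(=O)NC1=O`, 1410 nM

The read-out is a functional assay for agonist activity at Free fatty acid receptor 1 (Homo sapiens), read by FLIPR, in the presence of a further agent that is not named here; on this read-out higher numbers stand for an effect only at larger amounts of compound and lower numbers for an effect already at smaller amounts. Within the three measured compounds, compound 1 gives the highest number; compound 3 lies close to it, within the scatter, while compound 2 stands well apart with a number that is clearly lower. Within the data shown here, no pair of these three differs in a single place, so no step between them is counted.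

Compound 4 `O=C1NC(=O)C(Cc2ccc(Oc3ccc(Cl)cc3)cc2)S1` has not yet been measured. Against compound 1 the change is 4-chlorophenyl in place of 6-methylpyridin-2-yl on an oxygen on an aromatic ring. Both compounds whose aryloxy group is a carbon-only ring, compound 2 and compound 3, return lower numbers than compound 1, though compound 3 only within the scatter. A step toward a lower number, of moderate size and somewhat beyond the scatter, is therefore expected, a 2.9-fold lower number from compound 1 to compound 4 (0.46 log units; beyond the scatter). Compound 4 is estimated at 900 nM, with a range from 300 nM to 3000 nM.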

Compound 4, half-maximal effective concentration: 240 nM
Compound 4: middle estimate off by 3.8-fold (0.57 log units), on the high side, and the stated range ends above it.
By their numbers in this assay, from the lowest: compounds 2 and 4 (each within the scatter of the next); then compounds 3 and 1 (each within the scatter of the next).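

In this assay, among these compounds, 4-chlorophenyl in place of 6-methylpyridin-2-yl on an oxygen on an aromatic ring gives an 11-fold lower number from compound 1 to compound 4 (1.04 log units; beyond the scatter) with the rest of the molecule unchanged, and this is the only single-place step so far. The group on this oxygen can therefore move the number well beyond the scatter on its own, with the heavy-atom count of the group the same on both sides. No measurement on hand accounts for the size of this step.

The change replaces the ring nitrogen, the methyl and the chlorine-free ring all at once, so the compounds shown do not separate their contributions. Open too, going by these compounds, is whether a plain phenyl, or a bromine in place of the chlorine, would keep the lower number.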